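The source may report more compounds than this note shows. Statements on the series, on what has been measured and on what is new or still open speak of the compounds shown alone.

In a functional assay on VCaP cells (Homo sapiens) for antiproliferative activity, read by CCK-8 assay, with a stated time of 6 days (a lower number here means a stronger inhibitor, a higher number a weaker inhibitor), compound 1 `N#Cc1ccc(N2CCc3cc(-c4cnc5ccccc5c4)ccc3C2)cc1C(F)(F)F` gives only a limit, > 30000 nM. Within the data shown here, compound 2 `CCN(c1ccc(C#N)c(Cl)c1)c1cc(-c2ccoc2)ccc1C` gives 4010 nM in this assay, and that is the only number recorded here; the remaining value is the limit of > 30000 nM in this assay, at which 1 of the 2 values shown sits. Compound 3 `CCN(c1ccc(C#N)c(Cl)c1)c1cc(-n2cccn2)ccc1C` differs from compound 2 in one place: 1H-pyrazol-1-yl in place of furan-3-yl on an aromatic carbon. Among the measured compounds shown here, no step between measured compounds is available for comparison, so the size of this change in this assay is uncertain; a small shift, probably not beyond the scatter, is expected. The expected step is a 1.1-fold lower number from compound 2 to compound 3 (0.06 log units; within the scatter). Compound 3 is estimated at 3500 nM, with a range from 1000 nM to 12000 nM.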

Compound 3, half-maximal inhibitory concentration: 2340 nM
Beside the measured number, compound 3's estimate is 1.5-fold (0.17 log units) above it; the range from low to high includes it.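

In this assay, among these compounds, this is the first reading at this position, on an aromatic carbon para to a methyl group and meta to a large group: a 1.7-fold lower number from compound 2 to compound 3 (0.23 log units; within the scatter). Exchanging furan-3-yl for 1H-pyrazol-1-yl, a five-membered aromatic ring with 2 hetero atoms for one with 1, therefore keeps the number within the scatter. Nothing measured here accounts for the step.

Going by these compounds, what an amine or a carboxylic acid at this position would give in this assay remains open. Also open, on these data alone, is whether the same exchange would stay within the scatter on another core.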